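A few compounds are considered here, and "the series" means these few. Any claim that something is new, unique, unknown or untested is made for them only; others in the source may bear on it.

Among the measured compounds shown here, the three compounds measured so far share one core and differ only in the group on the oxygen next to the carbonyl. Compound 1 `CC(C)COC(=O)Nc1ccc([Se]C#N)cc1` gives, in an ADME assay on BEAS-2B cells (Homo sapiens) for cytotoxicity, read by MTT assay, with a stated time of 72 h (on this read-out lower numbers stand for stronger inhibition of growth and higher numbers for weaker inhibition of growth), 49500 nM. Compound 2 `CCCCCCOC(=O)Nc1ccc([Se]C#N)cc1` gives in this assay 35900 nM, and compound 3 `N#C[Se]c1ccc(NC(=O)OCc2ccc([N+](=O)[O-])cc2)cc1` gives 32800 nM. For the measured compounds named here, the one step that can be drawn among them, a 1.4-fold lower number from compound 1 to compound 2 (0.14 log units; within the scatter), is within the scatter. Compound 2 stands among the three numbers with both neighbours close: its gap to compound 3 and its gap to compound 1 are each within the scatter, so no order among the three can be read.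

Compound 4 `N#C[Se]c1ccc(NC(=O)Oc2ccccc2)cc1` is reached from compound 2 by phenyl in place of hexyl on an oxygen next to a carbonyl group. Going by the values given here, no measured step swaps a chain for an aromatic ring at this oxygen; the step from compound 1 to compound 2 only lengthens the chain, and compound 3, which carries a ring on this oxygen, gives a number within the scatter of compound 2. The data therefore give no reason to expect a step beyond the scatter in this assay, in either direction.

For compound 4 the expected value in this assay is 36000 nM, with a range from 15000 nM to 85000 nM, so that the expected step of a 1.0-fold higher number from compound 2 to compound 4 (0.00 log units; within the scatter) is flat.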

Compound 4, concentration for total growth inhibition: 38200 nM
For compound 4 the middle estimate is 1.1-fold (0.03 log units) below the measured one; measured number inside the range.
By their numbers in this assay, from the lowest: compounds 3, 2, 4 and 1 (each within the scatter of the next).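

Phenyl in place of hexyl on the oxygen next to a carbonyl group is the first swap of a chain for an aromatic ring of carbon only at this position, and in this assay it gives a 1.1-fold higher number from compound 2 to compound 4 (0.03 log units; within the scatter). The same kind of swap from the shorter chain, phenyl in place of isobutyl, gives a 1.3-fold lower number from compound 1 to compound 4 (0.11 log units; within the scatter), so neither chain can be told apart from the ring in this read-out, even though the two steps start from different chains. This extends the flat picture at this oxygen from chains alone to a swap between a saturated chain and an aromatic ring, and nothing at hand accounts for it.

What the compounds shown leave open is whether any group on this oxygen moves the number beyond the scatter in this assay, for instance a much longer chain, a chain ending in an amine or a carboxylic acid, or a pyridine ring. They also leave open whether a change elsewhere on the shared core would do so, since all four compounds differ only at this oxygen.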